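The compounds below may be only part of what the source reports. "The series", "measured", "known", "first", "only" and "open" are said of these compounds alone.

Compound 1 `Cc1oc(=O)oc1COC(=O)c1cccc(NC(=O)[C@@H]2C[C@H](SC3=C(C(=O)O)N4C(=O)[C@H]([C@@H](C)O)[C@H]4[C@H]3C)CN2)c1`: in an ADME assay for metabolic stability, read by LC-MS, with a stated time of 3 h, at pH 6.5, tested at 50 uM (on this read-out lower numbers stand for a less stable compound and higher numbers for a more stable compound), compound 1 gives > 95%, a limit of the assay.
Compound 2 `CCOC(=O)C1=C(S[C@@H]2CN[C@H](C(=O)Nc3cccc(C(=O)OCC)c3)C2)[C@H](C)[C@@H]2[C@@H]([C@@H](C)O)C(=O)N12`: in this assay compound 2 gives > 95%, a limit of the assay.
Compound 3 `CC(C)OC(=O)c1cccc(NC(=O)[C@@H]2C[C@H](SC3=C(C(=O)O)N4C(=O)[C@H]([C@@H](C)O)[C@H]4[C@H]3C)CN2)c1`: in this assay compound 3 gives > 95%, a limit of the assay.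

All three compounds share one core and differ only in the ester group attached to it. Compound 3 stands where every measured compound stands, at the limit of > 95% in this assay, at which 3 of the 3 values shown sit; its reading is a limit rather than a number. Going by the values given here, the one comparison between measured compounds, a step that the two limits leave unreadable from compound 1 to compound 3, cannot be sized, as both of its ends are limits.

Compound 4 `CCOC(=O)c1cccc(NC(=O)[C@@H]2C[C@H](SC3=C(C(=O)O)N4C(=O)[C@H]([C@@H](C)O)[C@H]4[C@H]3C)CN2)c1` has not yet been tested in this assay. It differs from compound 3 by hydrogen in place of methyl on a saturated chain carbon bound to an oxygen next to a carbonyl group and a saturated chain carbon. Among the compounds with values here, no measured step bears directly on this change, and the only step that touches the same ester position, a step that the two limits leave unreadable from compound 1 to compound 3, gives no size. Because compound 1, compound 2 and compound 3 all sit at the limit of > 95% in this assay, at which 3 of the 3 values shown sit, the expected step is a step that the limit leaves unreadable from compound 3 to compound 4, that is, none beyond the scatter. Compound 3 is the nearest measured point of reference. Compound 4 is therefore expected to read 97%, within a range of 88% to 100%, most likely reported once more as a limit.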

Compound 4, percent of the compound remaining: > 95%
Compound 4 was reported as a limit; the forecaster's own chance of this, stated with the estimate: 85%; the middle value does not contradict the limit.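

Compound 4 gives > 95% in this assay, a limit of the assay. Its steps from compound 1, compound 2 and compound 3 cannot be read, as each joins two limits: the limit of > 95% in this assay, at which 4 of the 4 values shown sit.

The compounds shown leave open whether changing the ester group alters the percent of compound remaining at all, and no value shown gives a number to compare.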